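Sulfamoyl in place of chloro on two cores

A few compounds are considered here, and "the series" means these few. Any claim that something is new, unique, unknown or untested is made for them only; others in the source may bear on it.

Compound 1 `Cc1ccc(-c2nn(-c3ccc(Cl)cc3)cc2C(CC(=O)c2ccc(Cl)cc2)C(=O)c2ccc(F)cc2)cc1` and compound 2 `Cc1ccc(-c2nn(-c3ccc(S(N)(=O)=O)cc3)cc2C(CC(=O)c2ccc(Cl)cc2)C(=O)c2ccc(F)cc2)cc1` share one core; compound 3 `Cc1ccc(-c2nn(-c3ccc(Cl)cc3)cc2-c2cc(-c3ccc(Cl)cc3)[nH]c2-c2ccc(F)cc2)cc1` and the still unmeasured compound 4 `Cc1ccc(-c2nn(-c3ccc(S(N)(=O)=O)cc3)cc2-c2cc(-c3ccc(Cl)cc3)[nH]c2-c2ccc(F)cc2)cc1` share another. The difference between the two cores is not broken down here. In a functional assay on the whole organism (strain Wistar albino) for inhibition, with Rattus norvegicus as the target, read by paw edema, with stated times of 1 h and 3 h, at a dose of 0.32 mmol/kg by the intraperitoneal route (on this read-out lower numbers stand for less inhibition and higher numbers for more inhibition at the one dose given (going by the name of the read-out)), compound 1 gives 19.4% and compound 2 gives 56.2%; the change sulfamoyl in place of chloro on an aromatic carbon yields a number 36.8 percentage points higher from compound 1 to compound 2 (beyond the scatter). In this assay compound 3 gives 21%, a number within the scatter of compound 1. The change sulfamoyl in place of chloro on an aromatic carbon is the same change at the same place. A step of like size is expected, a number 35 percentage points higher from compound 3 to compound 4 (beyond the scatter), because the same change gave a number 36.8 percentage points higher from compound 1 to compound 2 (beyond the scatter) and because compound 3 gives 21%. Compound 4 is therefore estimated at 56%, with the expected range from 38% to 70%.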

Compound 4, a percentage reported as inhibition, in the whole organism at one dose (the size of the read-out at that dose, not a potency): 66.7%
Estimate against measurement, compound 4: 10.7 percentage points below; the measured number falls inside the stated range.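

In this assay, sulfamoyl in place of chloro on an aromatic carbon also works on the second core: a number 45.7 percentage points higher from compound 3 to compound 4 (beyond the scatter). Set beside the earlier step, the change carries over between the two cores with no difference beyond the scatter: the same change on two cores in this assay, a number 36.8 percentage points higher (beyond the scatter) from compound 1 to compound 2 and a number 45.7 percentage points higher (beyond the scatter) from compound 3 to compound 4, 8.9 percentage points apart, within the scatter of two such steps. This rests on two pairs at a single dose, so it shows agreement on these two cores only, and it neither explains the step nor predicts it for any other core.

The compounds shown leave open whether a methylsulfonyl group or a carboxylic acid in the same place would give a step of like size on either core. Also open, on these data alone, is whether the step holds at other doses.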